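This account rests on a few compounds, and the source may have more. Where it says the series, first, only, none or still open, it means among the compounds named here.

Measured compounds:
compound 1 `COc1cc2nc(N3CCN(C(C)=O)[C@@H]4CCCC[C@@H]43)nc(N)c2cc1OC` gives 2.19 nM in a functional assay (strain Wistar) for antagonist activity at Alpha-1D adrenergic receptor (Rattus norvegicus), with a stated time of 30 min, in the presence of a further agent that is not named here; a lower number here means tighter binding, a higher number weaker binding
compound 2 `COc1cc2nc(N3CCN(C(C)=O)[C@H]4CCCC[C@H]43)nc(N)c2cc1OC` gives 1700 nM in this assay

Going by the values given here, compound 1 has the lower of the two numbers measured so far. Among the compounds with values here, the only measured step, a 780-fold higher number from compound 1 to compound 2 (2.89 log units; beyond the scatter), rests on the fact that compounds 1 and 2 differ only in the configuration as drawn: the two compounds are mirror images, and the large step shows how sharply this assay separates the two configurations.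

Compound 3 `COc1cc2nc(N3CCN(C(=O)OCc4ccccc4)[C@@H]4CCCC[C@@H]43)nc(N)c2cc1OC` is not yet measured. It keeps the configuration of compound 1 and differs from it by benzyloxy in place of methyl on a carbonyl carbon. The measured step does not bear on this change, since it concerns configuration, not the group on the carbonyl carbon. There is therefore no measured guide to the exchange of acetyl for benzyloxycarbonyl, and the expected step of a 1.8-fold higher number from compound 1 to compound 3 (0.26 log units; within the scatter) is set within the scatter, with a wide range to reflect that uncertainty. Compound 3 is estimated at 4 nM in this assay, between 0.7 nM and 25 nM.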

Compound 3, dissociation constant: 0.525 nM
The estimate for compound 3 lay 7.6-fold (0.88 log units) above the measured number; measured number outside the range, below it.
By their numbers in this assay, from the lowest: compound 3; then compound 1; then compound 2.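

In this assay, the place on the carbonyl carbon turns out to accept a far larger group than methyl: benzyloxy there gives a 4.2-fold lower number from compound 1 to compound 3 (0.62 log units; beyond the scatter), which means tighter binding. Going by these compounds alone, compounds 1 and 2 spoke only to configuration, so this is the first measured reading on the group at this place, and the step, though beyond the scatter, is small beside a 780-fold higher number from compound 1 to compound 2 (2.89 log units; beyond the scatter). The only fact at hand concerns configuration, so nothing here accounts for the lower number.

The exchange adds an oxygen and an aromatic ring at once, and the compounds shown do not separate the two; a methoxy or a benzyl group on the same carbonyl carbon would. Also open, from the compounds shown here alone, is how a longer chain without a ring, such as butyloxy, would read at this place.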